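A few compounds are considered here, and "the series" means these few. Any claim that something is new, unique, unknown or untested is made for them only; others in the source may bear on it.

compound 1 `CC(=O)N1N=C(c2ccc3ccccc3c2)OC1c1ccccc1Cl` gives 4.32 ug/mL
compound 2 `CC(=O)N1N=C(c2ccc3ccccc3c2)OC1c1ccccn1` gives 5.26 ug/mL

In a functional assay on HepG2 cells (Homo sapiens) for antiproliferative activity, read by MTT assay, with a stated time of 48 h (on this read-out lower numbers stand for stronger inhibition and higher numbers for weaker inhibition), compound 2 stands at 5.26 ug/mL and lies within the scatter of compound 1, so the pair cannot be ranked. Compound 3 `CC(=O)N1N=C(c2ccc3ccccc3c2)OC1c1cccnc1` differs from compound 2 as follows: pyridin-3-yl in place of pyridin-2-yl on a saturated ring carbon. Among the compounds with values here, the only measured step at this place is a 1.2-fold higher number from compound 1 to compound 2 (0.09 log units; within the scatter) (pyridin-2-yl in place of 2-chlorophenyl), and it stays within the scatter. Within the data shown here, no measurement yet tests an exchange between the two pyridinyl groups, so the evidence is thin. On that single step, the expected change in this assay is a 1.1-fold lower number from compound 2 to compound 3 (0.02 log units; within the scatter) and nothing beyond the scatter. For compound 3 the estimated value is 5 ug/mL with an expected range from 2.5 ug/mL to 10 ug/mL around it.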

Compound 3, half-maximal inhibitory concentration: 2.86 ug/mL
Beside the measured number, compound 3's estimate is 1.7-fold (0.24 log units) above it; the measured number falls inside the stated range.
By their numbers in this assay, from the lowest: compounds 3, 1 and 2 (each within the scatter of the next).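

In this assay, within the data shown here, the first exchange between the two pyridinyl groups on the saturated ring carbon gives a 1.8-fold lower number from compound 2 to compound 3 (0.26 log units; within the scatter); the atoms stay the same and only their joining differs, yet this shift of the ring nitrogen does not separate the two compounds. Pyridin-3-yl in place of 2-chlorophenyl gives a 1.5-fold lower number from compound 1 to compound 3 (0.18 log units; within the scatter), so all three groups tried at this position remain unranked and none of the steps here shows this position to be sensitive to the exchange. No measured evidence bears on this result.

Still open, going by these compounds, is whether any group on this carbon moves the number beyond the scatter, for example pyridin-4-yl, a carboxylic acid or a longer alkyl chain. On these data alone, the acetyl group and the naphthyl-bearing side of the shared core also remain untested by these compounds.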